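The compounds below may be only part of what the source reports. "The series", "measured", "known", "first", "only" and "open" are said of these compounds alone.

For the measured compounds named here, in a functional assay on PC-3 cells (Homo sapiens) for cytotoxicity, read by MTT assay, with a stated time of 48 h (on this read-out lower numbers stand for stronger inhibition and higher numbers for weaker inhibition), compound 1 `CC(=O)Oc1ccccc1C1CC(C)=NN1C(=O)CN(C(C)C)C(C)C` gives 24500 nM, the smaller of the two numbers measured so far, although the gap to the other lies within the usual scatter, so no ranking is possible. In this assay compound 2 `COc1ccccc1C1CC(C)=NN1C(=O)CN1CCC(OC)CC1` gives 27200 nM. Compound 3 `CC(=O)Oc1ccccc1C1CC(C)=NN1C(=O)CCl` has not been measured; it carries chloro in place of diisopropylamino on a saturated chain carbon bound to a carbonyl carbon. Going by the values given here, no measured pair shows this change, so the expected step of a 2.0-fold lower number from compound 1 to compound 3 (0.31 log units; beyond the scatter) is a guess: a modest move towards a lower number, barely beyond the scatter. Compound 3 is thus expected to give about 12000 nM, within 4000 nM to 40000 nM.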

Compound 3, half-maximal inhibitory concentration: 3580 nM
The estimate for compound 3 lay 3.4-fold (0.53 log units) above the measured number, outside the stated range (below it).
By their numbers in this assay, from the lowest: compound 3; then compounds 1 and 2 (each within the scatter of the next).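

Putting chloro in place of diisopropylamino on a saturated chain carbon bound to a carbonyl carbon gives a 6.8-fold lower number from compound 1 to compound 3 (0.84 log units; beyond the scatter) in this assay. This shows that the group at this place matters to the read-out, and that a single chlorine atom can stand in for the 7 heavy atoms of diisopropylamino without loss. Compound 1 and compound 2 differ in more than one place, so they could not show this.

Going by these compounds, whether the lower number comes from chloro itself or from the loss of the amine stays open; a compound with bromo, methyl or dimethylamino at this place would help to separate the two. Nothing measured here says why the number moved.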